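Compound 3 to compound 4: a step among limits

This account rests on a few compounds, and the source may have more. Where it says the series, first, only, none or still open, it means among the compounds named here.

Of the compounds shown here, three that share one core have been tested in an ADME assay on Huh7.5.1 cells (Homo sapiens) for cytotoxicity, read by WST assay, with a stated time of 48 h (on this read-out higher numbers stand for lower toxicity in this test and lower numbers for higher toxicity in this test), and none has yet given a number. Compound 1 `Cc1c(-c2ccc(Cc3ccc(C(C)(C)C)cc3)cc2)[nH]c2cccc(F)c2c1=O`, which carries tert-butyl, gives > 5000 nM, and this is a limit of the assay. Compound 2 `Cc1c(-c2ccc(Cc3ccc(C(C)(O)C(F)(F)F)cc3)cc2)[nH]c2cccc(F)c2c1=O`, with 1-hydroxy-1-(trifluoromethyl)ethyl in that place, gives > 2500 nM, which is likewise a limit. Compound 3 `Cc1c(-c2ccc(Cc3ccc(S(=O)(=O)C(F)(F)F)cc3)cc2)[nH]c2cccc(F)c2c1=O`, with (trifluoromethyl)sulfonyl there, gives > 2500 nM, and this too is a limit. Compound 3 therefore stands, like the other two, at a limit and not at a measured value.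

Compound 4 `Cc1c(-c2ccc(Cc3ccc(S(F)(F)(F)(F)F)cc3)cc2)[nH]c2cccc(F)c2c1=O` differs from compound 3 in a single group: a group of 6 heavy atoms (5 fluorine, 1 sulfur; no ring) in place of a group of 7 heavy atoms (1 carbon, 2 oxygen, 3 fluorine, 1 sulfur; no ring), on an aromatic carbon. Going by the values given here, three measured steps concern exchanges at this same place: a step that the two limits leave unreadable from compound 1 to compound 3, a step that the two limits leave unreadable from compound 2 to compound 3 and a step that the two limits leave unreadable from compound 1 to compound 2. None of them has a readable size, so they offer no measured effect to carry over to the new group. All three compounds nevertheless remain at limits in this assay. Going by a step that the two limits leave unreadable from compound 2 to compound 3, no step beyond the scatter is expected, in either direction, and the estimated change is a step that the limit leaves unreadable from compound 3 to compound 4. Compound 4 will most likely be reported as a limit as well. For compound 4 the estimated value is 4000 nM, with an expected range from 2000 nM to 10000 nM.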

Compound 4, half-maximal cytotoxic concentration: > 5000 nM
Compound 4 gave a limit, no number; the forecaster's own chance of this, stated with the estimate: 80%; at least 1.2-fold (0.09 log units) between middle value and limit.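

In this assay compound 4 gives > 5000 nM, which is a limit and not a number. With compound 1, compound 2 and compound 3 also at limits, none of the steps to compound 4 can be read. The compounds shown leave open how the four groups at this place compare in this assay, and what half-maximal cytotoxic concentration any of these compounds has.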